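The source may hold more compounds than are shown below. What is called first, only, known or untested is meant among the compounds shown, and "the series" means these compounds.

Compounds with a measured value:

Compound 1 `CN(C)C1(Cc2ccccc2)CCN(c2cc(C(F)(F)F)ccc2CNC(=O)Nc2ccc(CO)c(F)c2)CC1` — 81 nM
Compound 2 `CN(C)C1(Cc2ccccc2)CCN(c2cc(C(F)(F)F)ccc2CNC(=O)Nc2cccc3ccc(O)cc23)CC1` — 8.9 nM
Compound 3 `CN(C)C1(Cc2ccccc2)CCN(c2cc(C(F)(F)F)ccc2CNC(=O)Nc2ccc3cccnc3c2)CC1` — 42 nM

All three share the same core and differ only in the aromatic group attached to the amide-type nitrogen of the urea. In an assay on CHO cells for antagonist activity at transient receptor potential cation channel subfamily V member 1 (Homo sapiens), read by scintillation counting, with a stated time of 5 min, in the presence of a further agent that is not named here (on this read-out higher numbers stand for an effect only at larger amounts of compound and lower numbers for an effect already at smaller amounts), compound 3 stands second highest of the three numbers: its nearest neighbour is compound 1, a 1.9-fold lower number from compound 1 to compound 3 (0.29 log units; within the scatter), while the step of a 4.7-fold higher number from compound 2 to compound 3 (0.67 log units; beyond the scatter) lies beyond the scatter.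

Compound 4 `CN(C)C1(Cc2ccccc2)CCN(c2cc(C(F)(F)F)ccc2CNC(=O)Nc2cccc3ccncc23)CC1` has not yet been measured. It differs from compound 3 only in the arrangement of the same atoms: isoquinolin-8-yl in place of quinolin-7-yl on an amide-type nitrogen. For the measured compounds named here, no measured step here rearranges a bicyclic group while keeping its atoms; the only step between two bicyclic groups, a 4.7-fold higher number from compound 2 to compound 3 (0.67 log units; beyond the scatter), also changes a hydroxyl for a ring nitrogen, so it bears on this change only loosely. The two bicyclic compounds both gave lower numbers than compound 1, which suggests a bicyclic group is well tolerated at this position. Compound 4 is therefore expected to land close to compound 3, with the step of a 1.2-fold lower number from compound 3 to compound 4 (0.08 log units; within the scatter) estimated to stay within the scatter. The estimate for compound 4 in this assay is 35 nM, within a range from 10 nM to 120 nM.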

Compound 4, half-maximal effective concentration: 18.7 nM
Compound 4: the middle estimate sits 1.9-fold (0.27 log units) above what was measured; the range from low to high includes it.
By their numbers in this assay, from the lowest: compound 2; then compound 4; then compounds 3 and 1 (each within the scatter of the next).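

In this assay, rearranging the same atoms is enough to shift the number at this position: there is a 2.2-fold lower number from compound 3 to compound 4 (0.35 log units; beyond the scatter), even though the group counted under the same atoms, ring types, donors and acceptors is unchanged. A hydroxyl is not needed to come near compound 2, yet a real gap remains, with a 2.1-fold higher number from compound 2 to compound 4 (0.32 log units; beyond the scatter). There is also a 4.3-fold lower number from compound 1 to compound 4 (0.64 log units; beyond the scatter), but a two-ring group does not guarantee a clear gain over compound 1, since compound 3 goes against that pattern by staying within the scatter of compound 1.

No data here explain why the arrangement of these atoms matters. From the compounds shown here alone, it remains open how an isoquinolin-8-yl group carrying an amine or a methoxy group would behave, and whether another isoquinoline attachment point would give a lower number.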